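The compounds below may be only part of what the source reports. "The series", "measured", "known", "first", "only" and "open" are said of these compounds alone.

The measured compounds and their results in an assay on isolated protein (Mus musculus) for inhibition of IL15-IL15 receptor (Homo sapiens), read by resazurin assay, with stated times of 30 min and 2.5 days; on this read-out higher numbers stand for weaker inhibition and lower numbers for stronger inhibition:

compound 1, `Cn1c(Cc2nn(C)c(=O)c3ccccc23)nnc1SCCCCCCCCCCC(=O)Nc1ccc(Cl)cc1`, gives 20000 nM
compound 2, `Cn1c(Cc2nn(C)c(=O)c3ccccc23)nnc1SCCCCCCCCCCC(=O)Oc1ccc(Cl)cc1Cl`, gives 8700 nM
compound 3, `Cn1c(Cc2nn(C)c(=O)c3ccccc23)nnc1SCCCCCCCC(=O)Oc1ccc(Cl)cc1Cl`, gives 800 nM

Compound 3 gives the lowest of the three numbers, and its steps to compound 2 and compound 1 both lie beyond the scatter. How the core of compound 3 differs from that of compound 2 is not broken down here. Between compound 2 and compound 1 one change is made: (4-chlorophenyl)amino in place of 2,4-dichlorophenoxy on a carbonyl carbon. That change brought a 2.3-fold higher number from compound 2 to compound 1 (0.36 log units; beyond the scatter).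

Compound 4, `Cn1c(Cc2nn(C)c(=O)c3ccccc23)nnc1SCCCCCCCC(=O)Nc1ccc(Cl)cc1`, has not yet been measured. It is related to compound 3 by the same change, at the same place: (4-chlorophenyl)amino in place of 2,4-dichlorophenoxy on a carbonyl carbon. Since the two places read alike word for word, the change is the same, only made on the core of compound 3 instead of that of compound 2.

Going by the values given here, the expectation for compound 4 rests on the measured pair, because a 2.3-fold higher number from compound 2 to compound 1 (0.36 log units; beyond the scatter) is the only step of this kind on record. A step of about a 2.3-fold higher number from compound 3 to compound 4 (0.35 log units; beyond the scatter) is therefore expected from compound 3 to compound 4. On that basis compound 4 is estimated at 1800 nM, most likely between 700 nM and 5000 nM.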

Compound 4, half-maximal inhibitory concentration: 800 nM
Beside the measured number, compound 4's estimate is 2.3-fold (0.35 log units) above it, and the stated range covers the measured number.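

In this assay, (4-chlorophenyl)amino in place of 2,4-dichlorophenoxy on a carbonyl carbon gave no change at the digits printed from compound 3 to compound 4 (within the scatter). Set beside the earlier step, this result does not show that the change behaves differently on the two cores: the same change on two cores in this assay, a 2.3-fold higher number (0.36 log units; beyond the scatter) from compound 2 to compound 1 and no change at the digits printed (within the scatter) from compound 3 to compound 4, 2.3-fold (0.36 log units) apart, within the scatter of two such steps The change can therefore be said to carry between these two cores within the limits of the measurements, but with one pair on each core this does not establish the true size of its step, nor that it would carry to any other core in the series.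

The compounds shown leave open how a shorter or longer chain would read with either end group, and whether the step would hold on such chains. They also leave open what (2,4-dichlorophenyl)amino or 4-chlorophenoxy would give, which would separate the exchange of oxygen for nitrogen from the loss of one chlorine, and how a free carboxylic acid at the chain end would read.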